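Changing the sulfonyl group of compound 3

A few compounds are considered here, and "the series" means these few. Any claim that something is new, unique, unknown or untested is made for them only; others in the source may bear on it.

Values so far in a functional assay on HL-60 cells (Homo sapiens) for inhibition, read by CCK-8 assay, with a stated time of 48 h, tested at 20 uM (a lower number here means less inhibition of growth, a higher number more inhibition of growth at the concentration tested), for three compounds
Compound 1 `N#C/C(=C\c1ccccc1OS(=O)(=O)c1ccccc1[N+](=O)[O-])C(=O)Nc1nnc(Cc2ccccc2)s1` gives 12%
Compound 2 `N#C/C(=C\c1ccccc1OS(=O)(=O)c1ccccc1[N+](=O)[O-])C(=O)Nc1nnc(Cc2cccc(F)c2)s1` gives 23%
Compound 3 `Cc1ccc(S(=O)(=O)Oc2ccccc2/C=C(\C#N)C(=O)Nc2nnc(Cc3ccc(Cl)cc3)s2)cc1` gives 15%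

Compound 3 lies within the usual scatter of both other compounds. Compound 4 `N#C/C(=C\c1ccccc1OS(=O)(=O)c1ccccc1[N+](=O)[O-])C(=O)Nc1nnc(Cc2ccc(Cl)cc2)s1` differs from it by 2-nitrophenyl in place of 4-methylphenyl on a sulfonyl sulfur and by nothing else. Among the compounds with values here, the only measured step, a number 11 percentage points higher from compound 1 to compound 2 (beyond the scatter) for fluoro in place of hydrogen on an aromatic carbon, does not test this swap. However, compound 1 at 12% and compound 2 at 23% already carry 2-nitrophenyl, and neither stands beyond the scatter from compound 3 with its 4-methylphenyl. The expected step is therefore a number 3 percentage points higher from compound 3 to compound 4 (within the scatter) in this assay and stays within the scatter. Compound 4 is estimated at 18% with a likely range of 8% to 30% in this test.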

Compound 4, percent growth inhibition at one concentration: 19%
Compound 4: the middle estimate sits 1 percentage points below what was measured; the range from low to high includes it.
By their numbers in this assay, from the lowest: compounds 1, 3, 4 and 2 (each within the scatter of the next, the first and the last beyond it).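

On the sulfonyl sulfur, 2-nitrophenyl in place of 4-methylphenyl is now tested directly in this assay and gives a number 4 percentage points higher from compound 3 to compound 4 (within the scatter), so the two groups cannot be told apart here. Elsewhere, the added chloro gives a number 7 percentage points higher from compound 1 to compound 4 (within the scatter) and 4-chlorophenyl in place of 3-fluorophenyl gives a number 4 percentage points lower from compound 2 to compound 4 (within the scatter), so neither change can be read as a real difference. Nothing at hand explains these numbers. Still open, on these data alone, is whether a sulfonyl sulfur carrying a plain methyl, or a phenyl ring bearing an amine or a carboxylic acid, would move the number beyond the scatter.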